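Shortening the hydroxyalkyl ester chain of compound 1

The source may hold more compounds than are shown below. What is called first, only, known or untested is meant among the compounds shown, and "the series" means these compounds.

Compound 1 `CCCCC(O)CC(=O)O[C@H](CC=C(C)C)C1=CC(=O)c2c(O)ccc(O)c2C1=O` carries a (2-hydroxyhexyl)carbonyl group on the oxygen on a saturated carbon of the shared core. In a functional assay on DU-145 cells (Homo sapiens) for cytotoxicity, read by MTT assay (on this read-out higher numbers stand for weaker inhibition and lower numbers for stronger inhibition), compound 1 gives 45300 nM. Compound 2 `CC(C)=CC[C@@H](OC(=O)c1ccoc1)C1=CC(=O)c2c(O)ccc(O)c2C1=O` bears a (furan-3-yl)carbonyl group on that oxygen. In this assay compound 2 reaches only the assay limit, > 100000 nM. Compound 3 `COC(C)CO[C@H](CC=C(C)C)C1=CC(=O)c2c(O)ccc(O)c2C1=O` has a 2-methoxypropyl group there and gives 16600 nM in this assay. Of the two plain numbers, the higher belongs to compound 1. The gap to its nearest neighbour is a 2.7-fold lower number from compound 1 to compound 3 (0.44 log units; beyond the scatter). The third value, that of compound 2, is a limit, (the limit of > 100000 nM in this assay, at which 1 of the 3 values shown sits). The remaining steps read an at least 2.2-fold higher number from compound 1 to compound 2 (0.34 log units; beyond the scatter) and an at least 6.0-fold lower number from compound 2 to compound 3 (0.77 log units; beyond the scatter).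

Compound 4 `CCCC(O)CC(=O)O[C@H](CC=C(C)C)C1=CC(=O)c2c(O)ccc(O)c2C1=O` differs from compound 1 by hydrogen in place of methyl on a saturated chain carbon, four bonds along the chain from an oxygen on a saturated carbon. Among the measured compounds shown here, no measured step removes a methyl from a saturated chain; the steps known so far exchange the whole group on that oxygen, each modest or at least modest, and the group in compound 4 remains of the same kind as in compound 1. The expected change is therefore none beyond the scatter, a 1.1-fold higher number from compound 1 to compound 4 (0.04 log units; within the scatter). Compound 4 is estimated at 50000 nM in this assay, within a range from 20000 nM to 120000 nM.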

Compound 4, half-maximal inhibitory concentration: > 100000 nM
Compound 4: only a limit was reported; the forecaster's own chance of this, stated with the estimate: 15%; middle value at least 2.0-fold (0.30 log units) away from the limit.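

Working notes: the earlier steps exchanged the whole group on the oxygen, whereas this one removes a single methyl, butyl to propyl in the cut further out, and the position four bonds along the chain from an oxygen on a saturated carbon proves sensitive to it in this assay, reading an at least 2.2-fold higher number from compound 1 to compound 4 (0.34 log units; beyond the scatter). Compound 4 gives only a limit, which it shares with one other compound: the limit of > 100000 nM in this assay, at which 2 of the 4 values shown sit. The hydroxyalkyl ester of compound 4 also falls behind the ether of compound 3, with the step reading an at least 6.0-fold higher number from compound 3 to compound 4 (0.77 log units; beyond the scatter), while the step between compound 2 and compound 4 cannot be read, as both values are limits.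

Going by these compounds, the true size of the loss from compound 1 to compound 4 stays open, since only a bound on it is available, and two compounds do not establish a trend with chain length. Also open, on these data alone, are whether a longer chain than that of compound 1 would give a lower number, and whether an amine in place of the hydroxyl on the chain would keep the number of compound 1.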